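Methyl Addition on a Repositioned Stilbene-Type Core

The source may hold more compounds than are shown below. What is called first, only, known or untested is meant among the compounds shown, and "the series" means these compounds.

Measured compounds:
Compound 1, `COc1cc(/C=C/c2ccccc2)c(-c2ccccc2)c(OC)c1OC`, 89000 nM
Compound 2, `COc1cc(/C=C/c2ccc(C)cc2)c(-c2ccccc2)c(OC)c1OC`, 45000 nM
Compound 3, `C=C(c1ccccc1)c1cc(OC)c(OC)c(OC)c1-c1ccccc1`, 42000 nM

Three compounds were tested in a functional assay on HeLa cells (Homo sapiens) for cytotoxicity, read by MTT assay, with a stated time of 48 h; on this read-out lower numbers stand for stronger inhibition and higher numbers for weaker inhibition. Compound 1 gives 89000 nM. Compound 2 gives 45000 nM; it differs from compound 1 by methyl in place of hydrogen on an aromatic carbon, and the step was a 2.0-fold lower number from compound 1 to compound 2 (0.30 log units; within the scatter). Compound 3 gives 42000 nM and differs from compound 1 by 1-phenylethenyl in place of 2-phenylethenyl on an aromatic carbon, with the step of a 2.1-fold lower number from compound 1 to compound 3 (0.33 log units; beyond the scatter); compound 2 and compound 3 differ by a 1.1-fold lower number from compound 2 to compound 3 (0.03 log units; within the scatter).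

Compound 4, `C=C(c1ccc(C)cc1)c1cc(OC)c(OC)c(OC)c1-c1ccccc1`, has not yet been tested in this assay. It differs from compound 3 by methyl in place of hydrogen on an aromatic carbon, the same kind of change as that from compound 1 to compound 2: in both cases a phenyl becomes a 4-methylphenyl, though in one case within a 2-phenylethenyl and in the other within a 1-phenylethenyl, the two cores differing as described by 1-phenylethenyl in place of 2-phenylethenyl on an aromatic carbon.

Because the earlier step of a 2.0-fold lower number from compound 1 to compound 2 (0.30 log units; within the scatter) stayed within the scatter, the change from compound 3 to compound 4 is expected to be of comparable size, a 1.5-fold lower number from compound 3 to compound 4 (0.18 log units; within the scatter). This rests on one pair only, so the expectation is loose. Compound 4 is accordingly estimated at 28000 nM in this assay, with a plausible range from 12000 nM to 70000 nM.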

Compound 4, half-maximal inhibitory concentration: 28000 nM
For compound 4 middle estimate and measured number coincide at the digits printed; measured number inside the range.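

In this assay, the methyl change on the core of compound 3 gave a 1.5-fold lower number from compound 3 to compound 4 (0.18 log units; within the scatter), and set beside the same change on the core of compound 1, the two steps do not differ: the same change on two cores in this assay, a 2.0-fold lower number (0.30 log units; within the scatter) from compound 1 to compound 2 and a 1.5-fold lower number (0.18 log units; within the scatter) from compound 3 to compound 4, 1.3-fold (0.12 log units) apart, within the scatter of two such steps. With the methyl present on both sides, the exchange of the two ethenyl attachments gave a 1.6-fold lower number from compound 2 to compound 4 (0.21 log units; within the scatter), and only the combination of the methyl change with that exchange gave a step that clears the scatter, a 3.2-fold lower number from compound 1 to compound 4 (0.50 log units; beyond the scatter). This shows that the phenyl to 4-methylphenyl change behaved alike on these two cores, but since each methyl step lies within the scatter on its own, it does not show that the methyl changes the number on either core, and two cores and a single group are too little to support a general rule for the series.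

The compounds shown leave open what a longer chain such as propyl, an amine or a carboxylic acid would do in place of that methyl on either core. They also leave open whether any change to the second phenyl, which carries no substituent in all four compounds, would move the number further.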